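Cytotoxicity of Thymine Piperidines with Chlorinated Aryl Ethers

The compounds below may be only part of what the source reports. "The series", "measured", "known", "first", "only" and "open" are said of these compounds alone.

Measured compounds:
compound 1 `Cc1cn(C2CCN(Cc3cccc(Oc4ccccc4)n3)CC2)c(=O)[nH]c1=O`: > 64000 nM
compound 2 `Cc1cn(C2CCN(Cc3cccc(Oc4cccc(Cl)c4)n3)CC2)c(=O)[nH]c1=O`: > 64000 nM
compound 3 `Cc1cn(C2CCN(Cc3cccc(Oc4ccc(Cl)c(Cl)c4)c3)CC2)c(=O)[nH]c1=O`: 6100 nM

In an ADME assay on MRC5 cells (Homo sapiens) for cytotoxicity, read by fluorescence and resazurin assay, with a stated time of 3 days (on this read-out lower numbers stand for stronger inhibition and higher numbers for weaker inhibition), compound 1 gives > 64000 nM, which is a limit of the assay and not a number. Compound 2 likewise gives > 64000 nM, again a limit. Among the measured compounds shown here, compound 3 is the one compound with a number, 6100 nM. The change from compound 2 to compound 1 is hydrogen in place of chloro on an aromatic carbon, and its step is a step that the two limits leave unreadable from compound 2 to compound 1, because both values sit at the limit of > 64000 nM in this assay, at which 2 of the 3 values shown sit. How the core of compound 3 differs from that of compound 2 is not broken down here. Compound 4 `Cc1cn(C2CCN(Cc3cccc(Oc4cccc(Cl)c4)c3)CC2)c(=O)[nH]c1=O` has not yet been measured; it differs from compound 3 by hydrogen in place of chloro on an aromatic carbon, the same kind of change as from compound 2 to compound 1, though the place differs: there the site was meta to a large group, here it is ortho to a chloro group and para to a large group. The measured step gives no readable size, so the expectation rests on compound 3 at 6100 nM alone. Compound 4 is expected to show the step of a 3.3-fold higher number from compound 3 to compound 4 (0.52 log units; beyond the scatter), a weaker effect, and is estimated at 20000 nM, between 6000 nM and 64000 nM.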

Compound 4, half-maximal inhibitory concentration: 21000 nM
The estimate for compound 4 lay 1.1-fold (0.02 log units) below the measured number, and the stated range covers the measured number.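

In this assay the change from 3,4-dichlorophenoxy to 3-chlorophenoxy gives a 3.4-fold higher number from compound 3 to compound 4 (0.54 log units; beyond the scatter), so on the core of compound 3 the loss of this chloro, ortho to a chloro group and para to a large group, has a readable size. This one step does not show that the same size carries over to another core, and it comes from a single pair. On the other core, compound 1 and compound 2 both stand at a limit of the assay and not at a number, and the step between them cannot be read: the limit of > 64000 nM in this assay, at which 2 of the 4 values shown sit.

The compounds shown leave open how a 3,4-dichlorophenoxy group behaves on the core of compound 1. They also leave open what a fluoro, methoxy or nitrile group in place of the remaining chloro would give on either core.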